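A few compounds are considered here, and "the series" means these few. Any claim that something is new, unique, unknown or untested is made for them only; others in the source may bear on it.

Measured compounds:
compound 1, `COc1ccc(-n2cc(COc3ccc4oc(=O)ccc4c3)nn2)cc1`: 46800 nM
compound 2, `CC(=O)Nc1ccc(-n2cc(COc3ccc4oc(=O)ccc4c3)nn2)cc1`: "not determined" (no result reported)

Among the measured compounds shown here, in a functional assay on A549 cells (Homo sapiens) for cytotoxicity, read by MTT assay, with a stated time of 48 h (a higher number here means a weaker inhibitor, a lower number a stronger inhibitor), compound 1 gives 46800 nM, the only number in this set; compound 2 has no number, so compound 1 stands alone and nothing can be ranked against it. Compound 3, `O=c1ccc2cc(OCc3cn(-c4ccccc4[N+](=O)[O-])nn3)ccc2o1`, differs from compound 1 by 2-nitrophenyl in place of 4-methoxyphenyl on an aromatic nitrogen. For the measured compounds named here, no measured pair shows what such a change does, so the step from compound 1 is expected to stay within the usual scatter, as a 1.0-fold lower number from compound 1 to compound 3 (0.02 log units; within the scatter). Compound 3 is therefore estimated at 45000 nM, within 12000 nM to 160000 nM.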

Compound 3, half-maximal inhibitory concentration: 10200 nM
The estimate for compound 3 lay 4.4-fold (0.64 log units) above the measured number; measured number outside the range, below it.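

The group on this aromatic nitrogen does matter in this assay: 2-nitrophenyl in place of 4-methoxyphenyl gives a 4.6-fold lower number from compound 1 to compound 3 (0.66 log units; beyond the scatter), a modest step but beyond the scatter. The earlier compounds shown here could not show this, as they offered no pair to compare. Nothing available explains why the number falls.

On these data alone, whether the step comes from gaining the nitro group or from losing the methoxy group stays open, as both happen in one change. Also open, as far as these compounds go, is how an amine or a carboxylic acid on the phenyl ring would compare.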